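A few compounds are considered here, and "the series" means these few. Any claim that something is new, unique, unknown or untested is made for them only; others in the source may bear on it.

Working notes on the series. In a functional assay on ileum (strain Hartley) for agonist activity at 5-hydroxytryptamine receptor 3A (Cavia porcellus) (a higher number here means a more potent compound, by a factor of ten per unit of this negative logarithm, a lower number a less potent compound), compound 1 `CCc1cc(C)cc2nc(N3CCN(C)CC3)oc12` gives 6.46. Compound 3 `CC(C)c1cccc2nc(N3CCN(C)CC3)oc12` returns only a limit in this assay, < 4. Compound 2 `CCOC(=O)c1ccc2oc(N3CCN(C)CC3)nc2c1` likewise returns only a limit in this assay, < 4; (the limit of < 4 in this assay, at which 2 of the 3 values shown sit). Within the data shown here, compound 2 thus stands at the floor of the numbers in hand, and compound 1 is the only compound with a numerical value. Among the measured compounds shown here, no two measured compounds differ in a single place, so no step between them can be read off.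

Compound 4 `COc1ccc2oc(N3CCN(C)CC3)nc2c1` is not yet measured. It differs from compound 2 as methoxy in place of ethoxycarbonyl on an aromatic carbon, meta to a fused ring and para to a fused ring. The value of compound 1, 6.46, shows that the shared core can reach a measurable level. The expected step from compound 2 to compound 4 is a rise beyond the scatter, a number at least 1.00 log units higher from compound 2 to compound 4 (beyond the scatter). Compound 4 is estimated at 5 in this assay, within 4 to 6.2, with a fair chance that only a limit is reported again.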

Compound 4, negative logarithm of the half-maximal effective concentration: 4.78
Beside the measured number, compound 4's estimate is 0.22 log units above it, and the stated range covers the measured number.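

In this assay, among these compounds, the exchange of ethoxycarbonyl for methoxy, on an aromatic carbon meta to a fused ring and para to a fused ring, gives the only step the series can yet show: a number at least 0.78 log units higher from compound 2 to compound 4 (beyond the scatter). Compound 2 holds only a limit, < 4, so the step marks a minimum and not a full size: the limit of < 4 in this assay, at which 2 of the 4 values shown sit. What is new is that this position, with methoxy on it, gives a numerical reading, so the change from ethoxycarbonyl to methoxy here is enough to lift a compound clear of that limit.

On these data alone, whether the rise follows from methoxy itself or from the departure of ethoxycarbonyl stays open. As far as these compounds go, how an amine, a carboxylic acid or a longer alkoxy chain on this same carbon would read in this assay also stays open.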